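This account rests on a few compounds, and the source may have more. Where it says the series, first, only, none or still open, it means among the compounds named here.

Measured in a functional assay on BGC-823 cells (Homo sapiens) for cytotoxicity, read by MTT assay, with a stated time of 72 h; a higher number here means a weaker inhibitor, a lower number a stronger inhibitor:

- compound 1 `CN1[C@@H]2c3[nH]c4ccccc4c3C[C@H]1[C@H](C#N)N1[C@@H](CNC(=O)c3ccc(Cl)cc3)c3[nH]c4ccccc4c3C[C@@H]21` gives 110 nM
- compound 2 `CN1[C@@H]2c3[nH]c4ccccc4c3C[C@H]1[C@H](C#N)N1[C@@H](CNC(=O)c3ccc4ccccc4c3)c3[nH]c4ccccc4c3C[C@@H]21` gives 1110 nM
- compound 3 `CN1[C@@H]2c3[nH]c4ccccc4c3C[C@H]1[C@H](C#N)N1[C@@H](CNC(=O)c3cc4ccccc4[nH]3)c3[nH]c4ccccc4c3C[C@@H]21` gives 1690 nM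

Compound 3 has the highest number of the three in this assay, but its gap to compound 2 is within the scatter, shown by a 1.5-fold higher number from compound 2 to compound 3 (0.18 log units; within the scatter); only compound 1 stands clearly apart, as a 15-fold higher number from compound 1 to compound 3 (1.19 log units; beyond the scatter) shows. The step to compound 4 `CN1[C@@H]2c3[nH]c4ccccc4c3C[C@H]1[C@H](C#N)N1[C@@H](CNC(=O)/C=C/c3cccc(C(F)(F)F)c3)c3[nH]c4ccccc4c3C[C@@H]21` changes the amide group attached to the shared core: 2-(3-(trifluoromethyl)phenyl)ethenyl in place of 1H-indol-2-yl on a carbonyl carbon.

For the measured compounds named here, two measured steps bear on it. Replacing the 4-chlorophenyl with a larger group cost potency in both cases, a 10-fold higher number from compound 1 to compound 2 (1.00 log units; beyond the scatter) and a 15-fold higher number from compound 1 to compound 3 (1.19 log units; beyond the scatter), while swapping one larger group for another made no difference beyond the scatter, a 1.5-fold higher number from compound 2 to compound 3 (0.18 log units; within the scatter). Compound 4 again carries a larger group in that place, so the expectation is that it stays near compounds 2 and 3, with no step beyond the scatter, a 1.4-fold lower number from compound 3 to compound 4 (0.15 log units; within the scatter). Compound 4 is therefore estimated at 1200 nM in this assay, in the range 300 nM to 5000 nM.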

Compound 4, half-maximal inhibitory concentration: 910 nM
Compound 4: middle estimate off by 1.3-fold (0.12 log units), on the high side, within the range that was stated.
By their numbers in this assay, from the lowest: compound 1; then compounds 4, 2 and 3 (each within the scatter of the next).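

Compound 4 loses the five-membered aromatic ring and the hydrogen-bond donor of 1H-indol-2-yl and brings in a double bond and a trifluoromethyl group, yet the result stays within the scatter, with a 1.9-fold lower number from compound 3 to compound 4 (0.27 log units; within the scatter) and a 1.2-fold lower number from compound 2 to compound 4 (0.09 log units; within the scatter). Three quite different groups on this carbonyl carbon therefore give readings that cannot be told apart, while compound 1 remains the one that stands out, with an 8.3-fold higher number from compound 1 to compound 4 (0.92 log units; beyond the scatter). Nothing available here explains this result.

The compounds shown leave open what sets 4-chlorophenyl apart: a plain phenyl or a 4-fluorophenyl on the same carbonyl carbon would help separate the chlorine from the rest of the group. From the compounds shown here alone, how a group of another kind, such as a short chain ending in an amine, would read in this assay is also open.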